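A few compounds are considered here, and "the series" means these few. Any claim that something is new, unique, unknown or untested is made for them only; others in the source may bear on it.

Series notes on an assay on isolated protein for inhibition of protoporphyrinogen oxidase (Homo sapiens), read by capillary electrophoresis; a lower number here means a stronger inhibitor, a higher number a weaker inhibitor.

Measured so far:
compound 1 `CCOC(=O)CSc1nc2cc(-n3nc(C(C)(C)C)sc3=O)c(F)cc2s1` gives 340 nM in this assay
compound 2 `CCOC(=O)CSc1nc2cc(-n3nc(C(C)(C)C)sc3=O)c(Cl)cc2s1` gives 5820 nM in this assay
compound 3 `CCOC(=O)CSc1nc2cc(-n3nc(C(C)(C)C)sc3=O)c(Br)cc2s1` gives 15600 nM in this assay

Compound 3 carries the highest number of the three. The steps among the measured compounds are all swaps of the halogen on the aromatic carbon: a 17-fold higher number from compound 1 to compound 2 (1.23 log units; beyond the scatter), a 46-fold higher number from compound 1 to compound 3 (1.66 log units; beyond the scatter) and a 2.7-fold higher number from compound 2 to compound 3 (0.43 log units; beyond the scatter). Each of them lies beyond the scatter, and compound 3 sits at the weak end of this set, nearest to compound 2 and furthest from compound 1.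

The next step keeps the bromo and alters the thioether chain instead: compound 4 `C#CCSc1nc2cc(-n3nc(C(C)(C)C)sc3=O)c(Br)cc2s1` differs from compound 3 by ethynyl in place of ethoxycarbonyl on a saturated chain carbon bound to a sulfur. None of the three measured steps touches this part of the molecule; the halogen swaps give no information on what a change at the chain carbon bound to sulfur does in this assay. Going by the values given here, no measured step therefore bears on the move from compound 3 to compound 4, and the direction of the change is open.

With no guide from the series, the step of a 1.0-fold lower number from compound 3 to compound 4 (0.02 log units; within the scatter) is expected to stay within the scatter. The expected value for compound 4 is 15000 nM, with a deliberately wide range from 4000 nM to 60000 nM.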

Compound 4, inhibition constant: 20700 nM
Compound 4: the middle estimate sits 1.4-fold (0.14 log units) below what was measured; measured number inside the range.
By their numbers in this assay, from the lowest: compound 1; then compound 2; then compounds 3 and 4 (each within the scatter of the next).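

In this assay, the move from ethoxycarbonyl to ethynyl on the saturated chain carbon bound to a sulfur gives a 1.3-fold higher number from compound 3 to compound 4 (0.12 log units; within the scatter), so with the bromo held fixed, this first change at the chain leaves the number within the scatter, even though the hydrogen-bond acceptors of the ethoxycarbonyl group are absent from ethynyl and the group is smaller by heavy-atom count. In this small set, the position therefore tolerates replacing (ethoxycarbonyl)methyl with propargyl, and this chain step is small beside the halogen step a 46-fold higher number from compound 1 to compound 3 (1.66 log units; beyond the scatter). No measurement shown here accounts for the lack of a clear shift at the chain.

From the compounds shown here alone, what remains open is whether the same swap would also stay within the scatter on the fluoro compound, where the number is far lower and a chain effect might be easier to read than in the weak bromo pair. Going by these compounds, it is also open whether this tolerance extends to very different groups at this chain carbon, such as a free carboxylic acid, an amine or a longer alkyl chain.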